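The source may report more compounds than this note shows. Statements on the series, on what has been measured and on what is new or still open speak of the compounds shown alone.

Compound 1 `COc1cc(-c2nnsc2-c2ccc([N+](=O)[O-])cc2)cc(OC)c1OC` and compound 2 `COc1cc(-c2nnsc2-c2ccc(F)cc2)cc(OC)c1OC` share one core, and compound 3 `COc1ccc(-c2snnc2-c2cc(OC)c(OC)c(OC)c2)cc1` keeps it too. In an ADME assay on HMEC-1 cells (Homo sapiens) for antiproliferative activity (on this read-out higher numbers stand for weaker inhibition and lower numbers for stronger inhibition), compound 1 gives > 1000 nM, which is a limit of the assay. Compound 2 gives > 1000 nM, again a limit, so compound 2 has no exact number of its own. The next change places methoxy where compound 2 carries fluoro, on an aromatic carbon, para to a large group: methoxy in place of fluoro on an aromatic carbon. Among the measured compounds shown here, the one measured step that bears on it is a step that the two limits leave unreadable from compound 1 to compound 2. All the data show here is the limit of > 1000 nM in this assay, at which 2 of the 2 values shown sit, so no measured size can be carried over. The expected direction is therefore only a cautious one, towards stronger inhibition, and a result at the same limit would be no surprise. The estimated change is an at least 2.5-fold lower number from compound 2 to compound 3 (0.39 log units; beyond the scatter). For compound 3 the expected value is 400 nM, with an estimated range from 40 nM to 3000 nM.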

Compound 3, half-maximal inhibitory concentration: 24.6 nM
Compound 3: the middle estimate sits 16-fold (1.21 log units) above what was measured; measured number outside the range, below it.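

In this assay, methoxy in place of fluoro gives an at least 40-fold lower number from compound 2 to compound 3 (1.60 log units; beyond the scatter), and methoxy in place of nitro gives an at least 40-fold lower number from compound 1 to compound 3 (1.60 log units; beyond the scatter). This shows that the group at this position can matter a great deal, which the step from compound 1 to compound 2 could not show, as its two limits leave it unreadable. Both new sizes are only lower bounds, because one end of each step is a limit and not a number: the limit of > 1000 nM in this assay, at which 2 of the 3 values shown sit.

As far as these compounds go, whether methoxy is unusual here, or whether an ethoxy group or an amine would serve as well, stays open. Compound 3 also cannot tell whether the oxygen or the methyl part of methoxy carries the effect, and a hydroxy group at this position would help to separate the two.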